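The source may report more compounds than this note shows. Statements on the series, on what has been measured and on what is new or still open speak of the compounds shown alone.

Measured compounds in an assay on HEK293 cells for positive allosteric modulation of metabotropic glutamate receptor 5 (Homo sapiens), read by FLIPR, with a stated time of 1 h; on this read-out lower numbers stand for an effect already at smaller amounts and higher numbers for an effect only at larger amounts of compound:

compound 1 `CC(=O)N1CCc2nc(C#Cc3ccccc3)sc2C1` — > 10000 nM
compound 2 `O=C(C1CCCO1)N1CCc2nc(C#Cc3ccccc3)sc2C1` — 790 nM
compound 3 `O=C(C1CCCCC1)N1CCc2nc(C#Cc3ccccc3)sc2C1` — 167 nM

The value of compound 1 is a limit of this assay, not a number: the limit of > 10000 nM in this assay, at which 1 of the 3 values shown sits. Compound 3 carries the lowest number shown; the nearest measured value is that of compound 2, with a 4.7-fold lower number from compound 2 to compound 3 (0.67 log units; beyond the scatter). The other steps, an at least 12-fold lower number from compound 1 to compound 2 (1.10 log units; beyond the scatter) and an at least 59-fold lower number from compound 1 to compound 3 (1.77 log units; beyond the scatter), run from a limit and so only bound the gain.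

Compound 4 `CC1CCCC(C(=O)N2CCc3nc(C#Cc4ccccc4)sc3C2)C1` differs from compound 3 by methyl in place of hydrogen on a saturated ring carbon. Every measured step exchanges the whole group on the carbonyl carbon; none adds a methyl to a ring that is already present, so the measured steps bear on this change only loosely. The substituent on the carbonyl carbon clearly matters, but a single methyl on the six-membered ring is a much smaller change than any step measured so far. A step within the scatter, or at most a small move in either direction, is therefore expected for compound 4 in this assay, giving a 1.3-fold lower number from compound 3 to compound 4 (0.11 log units; within the scatter) as the estimate. For compound 4 the estimated value is 130 nM, with a range from 40 nM to 450 nM.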

Compound 4, half-maximal effective concentration: 100 nM
Compound 4: the middle estimate sits 1.3-fold (0.11 log units) above what was measured; low and high end bracket the measured number.
By their numbers in this assay, from the lowest: compounds 4 and 3 (each within the scatter of the next); then compound 2. At a limit, above all of these: compound 1.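

In this assay, methyl on a saturated ring carbon, two ring bonds from the ring atom that bears the large group, gives a 1.7-fold lower number from compound 3 to compound 4 (0.22 log units; within the scatter), so the cyclohexyl ring takes this added carbon with no change that can be told from the scatter. The 3-methylcyclohexyl group also keeps the clear distance from oxolan-2-yl that cyclohexyl showed, with a 7.9-fold lower number from compound 2 to compound 4 (0.90 log units; beyond the scatter). Compound 1 stands at a limit, so an at least 100-fold lower number from compound 1 to compound 4 (2.00 log units; beyond the scatter) only bounds the gain: the limit of > 10000 nM in this assay, at which 1 of the 4 values shown sits.

Open, from the compounds shown here alone, is whether methyl on other carbons of the ring reads the same, and whether a hydroxyl, an amine or an ethyl group is accepted at this place. Also open, going by these compounds, is how a phenyl ring or a longer chain on the carbonyl carbon compares with 3-methylcyclohexyl.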